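This account rests on a few compounds, and the source may have more. Where it says the series, first, only, none or still open, it means among the compounds named here.

Compound 1 `Cc1cc(-c2sc(Cc3cccc(C(F)(F)F)c3)nc2C)ccc1C(N)=O` sits at the low end of the three numbers in hand: in a functional assay on cells for agonist activity at G-protein coupled receptor 52 (Homo sapiens), read by AlphaScreen and cAMP accumulation, with a stated time of 30 min (a lower number here means that less compound is needed, a higher number that more compound is needed for the effect), compound 1 gives 73 nM. Compound 3 `CCc1cc(-c2sc(Cc3cccc(C(F)(F)F)c3)nc2C)ccc1C(N)=O` gives 83 nM in this assay, and the step of a 1.1-fold higher number from compound 1 to compound 3 (0.06 log units; within the scatter) is within the scatter, so the two compounds cannot be ordered. Compound 2 `Cc1cc(C(N)=O)ccc1-c1sc(Cc2cccc(C(F)(F)F)c2)nc1C`, in which the methyl stands on the other side of the ring that carries the carbamoyl group, gives 1400 nM in this assay, a number far beyond the scatter from compound 1.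

Compound 4 `Cc1nc(Cc2cccc(C(F)(F)F)c2)sc1-c1ccc(C(N)=O)c(F)c1` differs from compound 1 in one place: fluoro in place of methyl on an aromatic carbon.

Within the data shown here, no measured step bears directly on this change. Among the measured compounds shown here, the single step in hand, from compound 1 to compound 3, changes a saturated chain carbon and is within the scatter; the gap between compound 1 and compound 2 involves a shift of the methyl rather than its replacement. What is shown is only that the ring bearing the carbamoyl group is sensitive to where its small substituent sits. With nothing to point one way, a step in this assay of modest size in either direction is expected, most likely from compound 1 to compound 4 a 2.1-fold higher number from compound 1 to compound 4 (0.31 log units; beyond the scatter). Compound 4 is therefore estimated at 150 nM, with a range from 40 nM to 600 nM.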

Compound 4, half-maximal effective concentration: 380 nM
Estimate against measurement, compound 4: 2.5-fold (0.40 log units) below; low and high end bracket the measured number.
By their numbers in this assay, from the lowest: compounds 1 and 3 (each within the scatter of the next); then compound 4; then compound 2.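

In this assay, the position ortho to a carbamoyl group turns out to respond to the identity of its substituent and not only to where a small group sits: fluoro in place of methyl gives a 5.2-fold higher number from compound 1 to compound 4 (0.72 log units; beyond the scatter) and fluoro in place of ethyl gives a 4.6-fold higher number from compound 3 to compound 4 (0.66 log units; beyond the scatter) on the same aromatic carbon. Methyl and ethyl at this position could not be told apart, whereas fluoro stands clear of both, so this is the first change on this carbon that moves the number beyond the scatter. Nothing at hand accounts for this step in terms of any property of fluoro, methyl or ethyl.

The compounds shown leave open whether the higher number belongs to fluoro in particular or to any group that is not a saturated chain, a question that chloro, methoxy or plain hydrogen on this carbon would help to settle. They also leave open whether a longer chain, such as propyl or isopropyl, would stay close to methyl and ethyl here.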